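Swapping the aryl arm on a thromboxane synthase inhibitor

This account rests on a few compounds, and the source may have more. Where it says the series, first, only, none or still open, it means among the compounds named here.

compound 1 `O=C(O)CC/C=C\CC1COC(c2cccnc2)OC1c1cccnc1`: 220 nM
compound 2 `CC(C)(C)c1ccc(OC(C)(C)C2OCC(C/C=C\CCC(=O)O)C(c3cccnc3)O2)cc1`: 280 nM

In an assay for inhibition of Thromboxane-A synthase (Homo sapiens), using microsomes (on this read-out higher numbers stand for weaker inhibition and lower numbers for stronger inhibition), compound 1 gives 220 nM and compound 2 gives 280 nM. Compound 2 holds the higher of the two numbers, yet its gap to compound 1 lies within the scatter, so the two cannot be told apart. Compound 3 `CC(C)(C1OCC(C/C=C\CCC(=O)O)C(c2cccnc2)O1)S(=O)(=O)c1ccccc1` has not been measured. It differs from compound 2 in one place: phenylsulfonyl in place of 4-(tert-butyl)phenoxy on a saturated chain carbon bound to two saturated chain carbons and a saturated ring carbon. The rest of the structure is unchanged. Because compound 2 gives 280 nM and one aromatic ring is kept at the same place, the step of a 1.1-fold higher number from compound 2 to compound 3 (0.03 log units; within the scatter) is expected to be small, likely none beyond the scatter. For compound 3 the estimate in this assay is 300 nM, expected to fall between 100 nM and 900 nM.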

Compound 3, half-maximal inhibitory concentration: 40 nM
The estimate for compound 3 lay 7.5-fold (0.88 log units) above the measured number, and the stated range ends above it.
By their numbers in this assay, from the lowest: compound 3; then compounds 1 and 2 (each within the scatter of the next).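

In this assay, phenylsulfonyl in place of 4-(tert-butyl)phenoxy gives a 7.0-fold lower number from compound 2 to compound 3 (0.85 log units; beyond the scatter), so this position responds to the group it carries even when an aromatic ring is kept there. The swap alters both the link to the ring and the tert-butyl group at once, so the step cannot be assigned to either change alone. Nothing measured here explains the step.

The compounds shown leave open whether a plain phenoxy or a 4-(tert-butyl)phenylsulfonyl group would give a number closer to that of compound 2 or compound 3.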